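Moving two fluorines on compound 2

A few compounds are considered here, and "the series" means these few. Any claim that something is new, unique, unknown or untested is made for them only; others in the source may bear on it.

For the measured compounds named here, in a functional assay on Jurkat cells (Homo sapiens) (on this read-out higher numbers stand for weaker inhibition and lower numbers for stronger inhibition), compound 2 `CC(C)[C@H](NC(=O)COc1cccc2ccccc12)C(=O)N[C@@H](CC(=O)O)C(=O)COc1c(F)cccc1F` gives 2040 nM as the only true number so far. Compound 1 `CC(C)[C@H](NC(=O)COc1cccc2ccccc12)C(=O)N[C@@H](CC(=O)O)C(=O)COc1ccc2ccccc2c1` reports > 100000 nM as a limit. Going by the values given here, the one measured step (an at least 49-fold lower number from compound 1 to compound 2 (1.69 log units; beyond the scatter)) is large, lies beyond the scatter, and concerns the group on the same oxygen. Compound 3 `CC(C)[C@H](NC(=O)COc1cccc2ccccc12)C(=O)N[C@@H](CC(=O)O)C(=O)COc1ccc(F)c(F)c1` rearranges the fluorines (3,4-difluorophenyl in place of 2,6-difluorophenyl on an oxygen on a saturated carbon), with 3,4-difluorophenyl in place of 2,6-difluorophenyl. Among the compounds with values here, with compound 2 and that step as the only guide, a moderate move to a higher number in this assay is expected (a 3.9-fold higher number from compound 2 to compound 3 (0.59 log units; beyond the scatter)) rather than a return to the limit. Compound 3 is estimated at 8000 nM (expected range 1800 nM to 40000 nM).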

Compound 3, half-maximal inhibitory concentration: > 100000 nM
Compound 3 was reported as a limit; the forecaster's own chance of this, stated with the estimate: 15%; middle value at least 12-fold (1.09 log units) from the limit.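

In this assay, moving the two fluorines to give 3,4-difluorophenyl, with the same atoms joined differently, produces an at least 49-fold higher number from compound 2 to compound 3 (1.69 log units; beyond the scatter). Of the three groups shown on this oxygen, only 2,6-difluorophenyl gives a true number, so the presence of two fluorines alone is not enough and their placement on the ring matters. The step between compound 1 and compound 3 cannot be read, and both compounds stand at the same limit: the limit of > 100000 nM in this assay, at which 2 of the 3 values shown sit.

The compounds shown leave open whether fluorine is needed at all. An unsubstituted phenyl, 2-fluorophenyl or 2,6-dichlorophenyl on this oxygen would bear on that question.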